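This account rests on a few compounds, and the source may have more. Where it says the series, first, only, none or still open, it means among the compounds named here.

Among the measured compounds shown here, compound 1 `Cc1nn(C)c(Oc2ccc(Cl)cc2)c1/C=N\OCc1c(Cl)c(-c2ccc(F)cc2)nn1C` in a functional assay on HCT-116 cells (Homo sapiens) for antiproliferative activity, read by MTT assay, with a stated time of 72 h (a lower number here means a stronger inhibitor, a higher number a weaker inhibitor), gives 6030 nM, the higher of the two numbers measured so far. Compound 2 `Cc1nn(C)c(Oc2ccc(OC(F)(F)F)cc2)c1/C=N\OCc1c(Cl)c(-c2ccc(F)cc2)nn1C` gives 2310 nM in this assay, and the step of a 2.6-fold lower number from compound 1 to compound 2 (0.42 log units; beyond the scatter) rests on trifluoromethoxy in place of chloro on an aromatic carbon. Compound 3 `Cc1nn(C)c(Oc2ccc(Cl)cc2)c1/C=N\OCc1c(Cl)c(-c2ccc(Cl)cc2)nn1C` differs from compound 1 by chloro in place of fluoro on an aromatic carbon. For the measured compounds named here, no measured step touches a fluoro-to-chloro swap on this ring, so the only measured step offers no direct guide. A change of no more than the usual scatter is expected, so compound 3 is estimated at 5000 nM (range 2000 nM to 12000 nM), a step of a 1.2-fold lower number from compound 1 to compound 3 (0.08 log units; within the scatter).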

Compound 3, half-maximal inhibitory concentration: 4670 nM
The estimate for compound 3 lay 1.1-fold (0.03 log units) above the measured number; low and high end bracket the measured number.
By their numbers in this assay, from the lowest: compound 2; then compounds 3 and 1 (each within the scatter of the next).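

In this assay, going from 4-fluorophenyl to 4-chlorophenyl gives a 1.3-fold lower number from compound 1 to compound 3 (0.11 log units; within the scatter), so the two halogens cannot be told apart at this position, para to a large group. Among the compounds shown here, the earlier step changed a different ring, so this is the first reading of how this ring responds to a change. No available evidence explains this result.

The compounds shown leave open whether only a halogen gives this result here. An amine, a methoxy group or a carboxylic acid at the same position might give a clearly different number.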